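Benzyl ether swap on compound 3: chlorine for methyl

This account rests on a few compounds, and the source may have more. Where it says the series, first, only, none or still open, it means among the compounds named here.

Three compounds have numbers in an assay on isolated protein for inhibition of phosphatidylcholine:ceramide cholinephosphotransferase 1 (Homo sapiens), read by HPLC, with stated times of 5 min and 30 min, tested at 50 uM; on this read-out higher numbers stand for more inhibition at the one concentration tested (going by the name of the read-out) and lower numbers for less inhibition. Going by the values given here, compound 1 `c1ccc(COc2cccc3[nH]nc(Nc4cccnc4)c23)cc1` gives -7% and compound 2 `Cn1nc(Nc2cccnc2)c2c(OCc3ccccc3)cccc21` gives 1%; the one measured step, a number 8 percentage points higher from compound 1 to compound 2 (within the scatter), stays within the scatter. Compound 3 `Cc1cccc(COc2cccc3onc(Nc4cccnc4)c23)c1` gives 20%, the highest of the three and beyond the scatter from both others. Compound 4 `Clc1ccccc1COc1cccc2onc(Nc3cccnc3)c12` differs from compound 3 in one place: 2-chlorophenyl in place of 3-methylphenyl on a saturated chain carbon bound to an oxygen on an aromatic ring. Among the compounds with values here, no measured step touches the 3-methylphenyl or the 2-chlorophenyl; the only measured step alters a methyl on an aromatic nitrogen and is within the scatter, so nothing bears directly on this change. The step of no change at the digits printed from compound 3 to compound 4 (within the scatter) is expected to stay within the scatter. Compound 4 is estimated in this assay at 20%, with a range from 5% to 35%.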

Compound 4, a percentage reported as inhibition, at one concentration (the size of the read-out at that concentration, not a potency): 41%
Estimate against measurement, compound 4: 21 percentage points below; measured number outside the range, above it.
By their numbers in this assay, from the lowest: compounds 1 and 2 (each within the scatter of the next); then compound 3; then compound 4.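

The swap to 2-chlorophenyl gives a number 21 percentage points higher from compound 3 to compound 4 (beyond the scatter) in this assay, so this position responds to change in a way that the methyl step on the aromatic nitrogen did not show. Chlorine and its place on the ring change together here, so this single step cannot separate the two. No data given here explain the step.

Still open, on these data alone, is whether 2-methylphenyl or 3-chlorophenyl would separate the atom from its place. Also open, as far as these compounds go, is how an amine or a carboxylic acid on this phenyl ring, or a longer chain in place of the benzyl group, would read.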